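A few compounds are considered here, and "the series" means these few. Any claim that something is new, unique, unknown or untested is made for them only; others in the source may bear on it.

Measured in a functional assay on HCT-116 cells (Homo sapiens) for antiproliferative activity; on this read-out lower numbers stand for stronger inhibition and higher numbers for weaker inhibition:
- compound 1 `COc1ccc(-c2snnc2-c2cc(OC)c(OC)c(OC)c2)cc1OC` gives 50.9 nM
- compound 2 `COc1cc(-c2nnsc2-c2ccc(Cl)cc2)cc(OC)c1OC` gives 18.5 nM
- compound 3 `COc1cc(-c2nnsc2-c2ccc(F)cc2)cc(OC)c1OC` gives > 1000 nM (a limit, not a number)

Of the two true numbers, compound 1 stands highest at 50.9 nM and compound 2 is lower at 18.5 nM in this series. Compound 4 `COc1ccc(-c2snnc2-c2cc(OC)c(OC)c(OC)c2)cc1` has hydrogen in place of methoxy on an aromatic carbon, ortho to a methoxy group and meta to a large group hydrogen in place of methoxy on an aromatic carbon in the core of compound 1. For the measured compounds named here, no measured step covers this swap. The only one, an at least 54-fold higher number from compound 2 to compound 3 (1.73 log units; beyond the scatter) (fluoro in place of chloro on an aromatic carbon), concerns other groups, yet its large size argues for a wide range. In this assay the expected step is a 1.5-fold lower number from compound 1 to compound 4 (0.16 log units; within the scatter) and nothing beyond the scatter is expected. Compound 4 is estimated at 35 nM with an expected range from 9 nM to 200 nM in this read-out.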

Compound 4, half-maximal inhibitory concentration: 25 nM
Estimate against measurement, compound 4: 1.4-fold (0.15 log units) above; the range from low to high includes it.
By their numbers in this assay, from the lowest: compounds 2 and 4 (each within the scatter of the next); then compound 1. At a limit, above all of these: compound 3.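

In this assay hydrogen in place of methoxy gives a 2.0-fold lower number from compound 1 to compound 4 (0.31 log units; beyond the scatter) so this methoxy group is not needed for activity in the core of compound 1. The swap on the remaining methoxy carbon gives a 1.4-fold higher number from compound 2 to compound 4 (0.13 log units; within the scatter) and leaves methoxy and chloro level there, while an at least 40-fold lower number from compound 3 to compound 4 (1.60 log units; beyond the scatter) sets fluoro apart. Compound 3 gives > 1000 nM as a limit of the assay and not a number.

Open, as far as these compounds go, is whether an amine or a hydroxyl on that carbon tracks chloro and methoxy or tracks fluoro. Also open, from the compounds shown here alone, is whether hydrogen on that carbon keeps the activity.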